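The source may hold more compounds than are shown below. What is called first, only, known or untested is meant among the compounds shown, and "the series" means these compounds.

Going by the values given here, compound 2 `CCc1cc(CN2CC(C(=O)O)C2)sc1-c1noc(-c2ccc(Oc3ccccc3C)cc2)n1` gives 35% in a functional assay on the whole organism (spleen, spleen, strain LEW) for inhibition, with Rattus norvegicus as the target, with a stated time of 4 days, at a dose of 1 mg/kg by the oral route (on this read-out higher numbers stand for more inhibition at the one dose given (going by the name of the read-out) and lower numbers for less inhibition), and stands lowest of the two numbers so far. Its nearest neighbour, compound 1 `CCc1cc(CN2CC(C(=O)O)C2)sc1-c1noc(-c2ccc(Oc3ccccc3OC)cc2)n1`, gives 74%; the step between them was a number 39 percentage points lower from compound 1 to compound 2 (beyond the scatter), arising from methyl in place of methoxy on an aromatic carbon. Compound 3 `CCc1ccccc1Oc1ccc(-c2nc(-c3sc(CN4CC(C(=O)O)C4)cc3CC)no2)cc1` differs from compound 2 by methyl in place of hydrogen on a saturated chain carbon bound to an aromatic carbon. Among the compounds with values here, no measured step reads methyl to ethyl, and the one known step concerns a different change, so it gives no direct guide; a step no larger than the scatter is expected. For compound 3 the estimated value in this assay is 38%, between 12% and 65%. The expected step is a number 3 percentage points higher from compound 2 to compound 3 (within the scatter).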

Compound 3, a percentage reported as inhibition, in the whole organism at one dose (the size of the read-out at that dose, not a potency): 62%
For compound 3 the middle estimate is 24 percentage points below the measured one, within the range that was stated.
By their numbers in this assay, from the lowest: compound 2; then compound 3; then compound 1.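

In this assay the single added carbon at this position is not a silent change: going from methyl to ethyl gives a number 27 percentage points higher from compound 2 to compound 3 (beyond the scatter) and recovers much of what the methyl lost against methoxy. Ethyl still falls short of methoxy, with a number 12 percentage points lower from compound 1 to compound 3 (beyond the scatter) as the remaining gap, so the three groups now order as methyl, ethyl, methoxy. Nothing given here explains either step.

From the compounds shown here alone, whether a longer chain such as propyl would extend this rise remains open. So does how ethoxy or a chlorine atom would compare with methoxy here.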